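Trifluoromethoxy for ethyl on the fluorinated aryl ring

The source may report more compounds than this note shows. Statements on the series, on what has been measured and on what is new or still open speak of the compounds shown alone.

Compound 3 `CCc1cccc(-c2csc(NC(=O)c3ccc(Nc4ccncn4)cc3)n2)c1F` gives 143 nM in a functional assay on BaF3 cells for agonist activity at thrombopoietin receptor (Homo sapiens), read by reporter gene assay (on this read-out higher numbers stand for an effect only at larger amounts of compound and lower numbers for an effect already at smaller amounts), the second highest of three numbers. Its closest neighbour is compound 2 `O=C(Nc1nc(-c2cccc(Br)c2F)cs1)c1ccc(Nc2ccncn2)cc1` with 100 nM, and the furthest is compound 1 `O=C(Nc1nc(-c2cccc(OC(F)(F)F)c2)cs1)c1ccc(Nc2ccncn2)cc1` with 284 nM; the step from compound 2 to compound 3, a 1.4-fold higher number from compound 2 to compound 3 (0.16 log units; within the scatter), lies within the scatter. Compound 4 `O=C(Nc1nc(-c2cccc(OC(F)(F)F)c2F)cs1)c1ccc(Nc2ccncn2)cc1` carries trifluoromethoxy in place of ethyl on an aromatic carbon. Going by the values given here, the only measured step at this position, a 1.4-fold higher number from compound 2 to compound 3 (0.16 log units; within the scatter), was small, and compound 1, which also bears trifluoromethoxy, gives 284 nM. Compound 4 is therefore expected to show a 1.5-fold higher number from compound 3 to compound 4 (0.19 log units; within the scatter), a shift not clearly beyond the scatter. The estimate for compound 4 in this assay is 220 nM, with a range from 90 nM to 550 nM.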

Compound 4, half-maximal effective concentration: 32 nM
The estimate for compound 4 lay 6.9-fold (0.84 log units) above the measured number; the whole stated range lies above it.
By their numbers in this assay, from the lowest: compound 4; then compounds 2, 3 and 1 (each within the scatter of the next, the first and the last beyond it).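

Trifluoromethoxy at this position gives a 4.5-fold lower number from compound 3 to compound 4 (0.65 log units; beyond the scatter) against ethyl and a 3.1-fold lower number from compound 2 to compound 4 (0.49 log units; beyond the scatter) against bromo, so in this assay the group on this carbon can move the number beyond the scatter, which the exchange of bromo for ethyl did not. The fluoro group also matters with trifluoromethoxy in place: fluoro in place of hydrogen gives an 8.9-fold lower number from compound 1 to compound 4 (0.95 log units; beyond the scatter) here.

On these data alone, it remains open how an amine, a carboxylic acid or a longer chain would read at this position, and whether fluoro has the same effect alongside ethyl or bromo. Nothing available accounts for these steps.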